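A few compounds are considered here, and "the series" means these few. Any claim that something is new, unique, unknown or untested is made for them only; others in the source may bear on it.

The compounds measured in a physicochemical assay for solubility, read by spectrophotometry, in phosphate buffer, with a stated time of 18 h, at pH 7.4 (a higher number here means a more soluble compound, a lower number a less soluble compound), are:

Compound 1, `CCc1ccc(-c2nc3c(c(C)nn3-c3ccccc3)c(-c3ccccc3)c2C#N)cc1`: 47000 nM
Compound 2, `CCc1ccc(-c2nc3c(c(C)nn3-c3ccccc3)c(-c3cccc(O)c3)c2C#N)cc1`: 18000 nM
Compound 3, `Cc1ccccc1-c1nc2c(c(C)nn2-c2ccccc2)c(-c2ccccc2O)c1C#N`: 21000 nM

Compound 3 stands second highest of the three numbers. Its nearest neighbour is compound 2, a gap within the usual scatter, so the two cannot be told apart on these data. Compound 1 sits furthest from compound 3, beyond the scatter, and is the most soluble of the three. For the measured compounds named here, the one measured single-point step, a 2.6-fold lower number from compound 1 to compound 2 (0.42 log units; beyond the scatter), is the change that separates compound 1 from compound 2.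

Compound 4, `CCc1cccc(-c2nc3c(c(C)nn3-c3ccccc3)c(-c3ccccc3O)c2C#N)c1`, differs from compound 3 in one place: 3-ethylphenyl in place of 2-methylphenyl on an aromatic carbon. The measured step from compound 1 to compound 2 concerns a hydroxy group entering elsewhere and does not touch the aryl group changed here, so it offers no direct guide. Going by the values given here, no pair among the measured compounds isolates an exchange of this kind. Compound 4 is therefore expected to land close to compound 3, and the implied step a 1.1-fold lower number from compound 3 to compound 4 (0.04 log units; within the scatter) is expected to stay within the scatter. Compound 4 is estimated at 19000 nM, with a range from 8000 nM to 42000 nM.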

Compound 4, solubility: 11000 nM
For compound 4 the middle estimate is 1.7-fold (0.24 log units) above the measured one; measured number inside the range.
By their numbers in this assay, from the lowest: compounds 4, 2 and 3 (each within the scatter of the next); then compound 1.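

In this assay, the exchange of 2-methylphenyl for 3-ethylphenyl gives a 1.9-fold lower number from compound 3 to compound 4 (0.28 log units; within the scatter). For the compounds shown here, this is the first measured change at this position, next to the ring nitrogen and ortho to a cyano group, and the step cannot be told apart from the scatter. The earlier step concerned a hydroxy group on a different aryl group, so only this result shows that this particular exchange at this position leaves no readable difference; nothing on hand offers an explanation for the result.

The compounds shown leave open whether an aryl group carrying an amine, a carboxylic acid or a longer chain than ethyl would give a step beyond the scatter here. They also leave open how the length of the chain and its place on the aryl ring each contribute on their own, since this exchange alters both together.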